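Amide aryl variation in a chlorophenylpiperidine series

A few compounds are considered here, and "the series" means these few. Any claim that something is new, unique, unknown or untested is made for them only; others in the source may bear on it.

Measured compounds:
Compound 1 `Cc1ccc(C(=O)N[C@@H](C(=O)N2CCC(c3ccc(Cl)cc3)CC2)C(C)C)cc1` gives 25 nM in an assay on THP-1 cells for displacement of a labelled ligand from C-C chemokine receptor type 1 (Homo sapiens); on this read-out higher numbers stand for weaker inhibition and lower numbers for stronger inhibition.
Compound 2 `CC[C@@H](C)[C@@H](NC(=O)c1ccccc1)C(=O)N1CCC(c2ccc(Cl)cc2)CC1` gives 45 nM in this assay.

Compound 1 has the lowest of the two numbers shown; compound 2 sits within the scatter of it, so no order between them can be read. Compound 3 `CC(C)[C@@H](NC(=O)c1cccc(F)c1)C(=O)N1CCC(c2ccc(Cl)cc2)CC1` differs from compound 1 by 3-fluorophenyl in place of 4-methylphenyl on a carbonyl carbon. Among the measured compounds shown here, no measured pair shows a step of this kind, so its size and direction are not known. The change is expected to be small, without clear direction, giving an estimated step of a 1.6-fold higher number from compound 1 to compound 3 (0.20 log units; within the scatter). Compound 3 is therefore estimated at 40 nM, with a range from 12 nM to 130 nM.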

Compound 3, half-maximal inhibitory concentration: 24 nM
Beside the measured number, compound 3's estimate is 1.7-fold (0.22 log units) above it, within the range that was stated.
By their numbers in this assay, from the lowest: compounds 3, 1 and 2 (each within the scatter of the next).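

In this assay, among the compounds shown here, 3-fluorophenyl in place of 4-methylphenyl on a carbonyl carbon gives a 1.0-fold lower number from compound 1 to compound 3 (0.02 log units; within the scatter), the first step that can be read at this position. The two groups cannot be told apart here, so a change of both ring substituent and its place on the ring leaves the read-out within the scatter. No evidence on the cause of this result is at hand.

On these data alone, whether a carboxylic acid or an amine in place of these aryl groups would hold the read-out remains open. Compound 2 differs from compound 1 and compound 3 in more than one place, so the effect of its longer side chain cannot be separated.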